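From Cyclohexyl to Methylsulfonyl Pyrrolidine: One Agonist Step

The source may hold more compounds than are shown below. What is called first, only, known or untested is meant among the compounds shown, and "the series" means these compounds.

For the measured compounds named here, compound 1 `O=[N+]([O-])c1ccc(CN(Cc2ccc(Cl)cc2)CC2CCCCC2)s1` is the only member of this set with a number: in a functional assay on HEK293 cells for agonist activity at nuclear receptor subfamily 1 group D member 1 (Homo sapiens), read by a luciferase reporter, with a stated time of 24 h (on this read-out lower numbers stand for an effect already at smaller amounts and higher numbers for an effect only at larger amounts of compound), compound 1 gives 7400 nM. Compound 2 `CC(C)(C)OC(=O)N1CCC(N(Cc2ccc(Cl)cc2)Cc2ccc([N+](=O)[O-])s2)CC1` was also run in this assay, but for compound 2 the entry reads "not determined" (no result reported), so no result was reported. Compound 3 `CS(=O)(=O)N1CCC(CN(Cc2ccc(Cl)cc2)Cc2ccc([N+](=O)[O-])s2)C1` differs from compound 1 in one place: 1-(methylsulfonyl)pyrrolidin-3-yl in place of cyclohexyl on a saturated chain carbon bound to an amine nitrogen. Going by the values given here, no step between two measured compounds is available to show how large such a change might be. The step of a 1.1-fold higher number from compound 1 to compound 3 (0.03 log units; within the scatter) is therefore expected to be small, in either direction, and not clearly beyond the scatter. Compound 3 is estimated at 8000 nM, between 2500 nM and 25000 nM.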

Compound 3, half-maximal effective concentration: 570 nM
For compound 3 the middle estimate is 14-fold (1.15 log units) above the measured one; the measured number lies below the stated range.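

In this assay, the place on a saturated chain carbon bound to an amine nitrogen proves sensitive to what it carries: 1-(methylsulfonyl)pyrrolidin-3-yl in place of cyclohexyl gives a 13-fold lower number from compound 1 to compound 3 (1.11 log units; beyond the scatter). For the compounds shown here, the earlier compounds offered no step at all, so this is the first measure of how much a change here can matter. Nothing available accounts for the size of this step. The compounds shown do not separate the change of ring from the methylsulfonyl group itself. Going by these compounds, whether an acetyl group on the same pyrrolidine nitrogen, or a methylsulfonyl group on a piperidine ring, would keep this gain remains open.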